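From chloro to methoxy in a cell growth assay

This account rests on a few compounds, and the source may have more. Where it says the series, first, only, none or still open, it means among the compounds named here.

Compound 1 `Cc1nc(-c2ccc(Cl)cc2)sc1C(=O)CSc1nc(-c2ccccc2)c(C#N)c(=O)[nH]1` gives 27600 nM here
Compound 2 `Cc1nc(-c2ccc(Cl)cc2)sc1C(=O)CSc1nc(-c2cccc(Cl)c2)c(C#N)c(=O)[nH]1` gives 40100 nM here
Compound 3 `COc1ccc(-c2nc(SCC(=O)c3sc(-c4ccc(Cl)cc4)nc3C)[nH]c(=O)c2C#N)cc1OC` gives 38600 nM here

These three values come from a functional assay on U-87MG ATCC cells for antiproliferative activity against U-87 MG (Homo sapiens), read by MTT assay, with a stated time of 48 h (a lower number here means a stronger inhibitor, a higher number a weaker inhibitor), and compound 1 stands level with the other two, as its steps to both lie within the scatter.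

Compound 4 `COc1ccc(-c2nc(C)c(C(=O)CSc3nc(-c4ccccc4)c(C#N)c(=O)[nH]3)s2)cc1` keeps the core of compound 1 and alters one group, with methoxy in place of chloro on an aromatic carbon, so that 4-chlorophenyl becomes 4-methoxyphenyl.

Within the data shown here, no measured step touches the 4-chlorophenyl group, so the evidence is only indirect. All three steps alter a different aryl group. One is a 1.5-fold higher number from compound 1 to compound 2 (0.16 log units; within the scatter) with chloro in place of hydrogen, and another is a 1.4-fold higher number from compound 1 to compound 3 (0.15 log units; within the scatter) with 3,4-dimethoxyphenyl in place of phenyl. The closest in kind is a 1.0-fold lower number from compound 2 to compound 3 (0.02 log units; within the scatter) with 3,4-dimethoxyphenyl in place of 3-chlorophenyl. All three are small, so no step beyond the scatter is expected in this assay in either direction.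

The expected change is a 1.2-fold higher number from compound 1 to compound 4 (0.06 log units; within the scatter) by this estimate.

The estimated value for compound 4 is 32000 nM with an expected range from 14000 nM to 70000 nM around it.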

Compound 4, half-maximal inhibitory concentration: 57300 nM
Compound 4: middle estimate off by 1.8-fold (0.25 log units), on the low side, within the range that was stated.
By their numbers in this assay, from the lowest: compounds 1, 3, 2 and 4 (each within the scatter of the next, the first and the last beyond it).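

In this assay, among these compounds, replacing 4-chlorophenyl with 4-methoxyphenyl gives a 2.1-fold higher number from compound 1 to compound 4 (0.32 log units; beyond the scatter), the only step in this set that lies beyond the scatter. Among the compounds shown here, the earlier steps all altered the other aryl group, so this is the first direct sign that the group on this aromatic carbon, para to a large group, can shift the number, if only modestly. The change removes one chlorine and brings in a carbon and an oxygen, with one more hydrogen-bond acceptor, but nothing measured here explains why the number rises.

The compounds shown cannot separate the effect of losing chloro from that of gaining methoxy, and a plain phenyl, a fluoro, an amine or a longer ether such as ethoxy at this place would help to pull those two apart. From the compounds shown here alone, it also remains open whether the same swap would give a similar step with the 3-chlorophenyl of compound 2 or the 3,4-dimethoxyphenyl of compound 3 in place of the phenyl of compound 1.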